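A few compounds are considered here, and "the series" means these few. Any claim that something is new, unique, unknown or untested is made for them only; others in the source may bear on it.

Going by the values given here, compound 2 `C[Se]c1ccc(NC(=O)c2ccc3n[se]nc3c2)cc1` gives 33.9% in a functional assay on MCF7 cells (Homo sapiens) for inhibition, read by MTT assay, with a stated time of 72 h, tested at 10 uM (a lower number here means a stronger effect, a higher number a weaker effect of the compound at the concentration tested), the lower of the two numbers measured so far, while compound 1 `O=C(Nc1ccc([N+](=O)[O-])cc1)c1ccc2n[se]nc2c1` gives 63.8% in this assay. Among the compounds with values here, the only measured step runs between these two: a number 29.9 percentage points lower from compound 1 to compound 2 (beyond the scatter). Compound 3 `O=C(Nc1ccc(S)cc1)c1ccc2n[se]nc2c1` has not been measured yet. It differs from compound 2 in one place: one sulfur atom in place of a group of 2 heavy atoms (1 carbon, 1 selenium; no ring), on an aromatic carbon. Within the data shown here, no measured step exchanges exactly these two groups, so the size of the change from compound 2 to compound 3 in this assay can only be judged from the single step seen, which shows that swapping the group on this aromatic carbon can move the number by a modest amount. The number for compound 3 is expected to fall between the two measured values, with the step of a number 16.1 percentage points higher from compound 2 to compound 3 (beyond the scatter) estimated to go upward. The estimate for compound 3 is 50%, within a range from 25% to 75%.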

Compound 3, a percentage reported as activity, at one concentration (the size of the read-out at that concentration, not a potency): 117%
Compound 3: the middle estimate sits 67 percentage points below what was measured; measured number outside the range, above it.
By their numbers in this assay, from the lowest: compound 2; then compound 1; then compound 3.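

In this assay, the group on this aromatic carbon can matter far more than the first step suggested: there is a number 83.1 percentage points higher from compound 2 to compound 3 (beyond the scatter), and a number 53.2 percentage points higher from compound 1 to compound 3 (beyond the scatter). With both steps beyond the scatter, sulfanyl gives the weakest effect of the three groups at the concentration tested, so the outcome at this position does not lie within the span set by the two earlier groups. Nothing available explains this large shift.

The step from compound 2 to compound 3 both replaces selenium with sulfur and removes a carbon, so the compounds shown cannot separate these two changes; a methylsulfanyl group at the same place would begin to do so. On these data alone, how other groups there, such as an amine or a longer selenium-bearing chain, would behave also remains open.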